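Compound 3 to compound 4: acetamido for phenoxy

The source may report more compounds than this note shows. Statements on the series, on what has been measured and on what is new or still open speak of the compounds shown alone.

Three compounds in this series have numbers in a functional assay for agonist activity at G protein-coupled receptor 88 (Homo sapiens), read by HTRF and cAMP accumulation; on this read-out higher numbers stand for an effect only at larger amounts of compound and lower numbers for an effect already at smaller amounts. Compound 1 `CC[C@H](C)[C@H](N)CN(C(=O)[C@@H]1C[C@H]1c1cccc(C)c1)c1ccc(-c2ccccc2)cc1` gives 1200 nM, compound 2 `Cc1ccc(-c2ccc(N(C[C@@H](N)CC(C)C)C(=O)[C@@H]3C[C@H]3c3ccccc3)cc2)cc1` gives 360 nM, and compound 3 `CC[C@H](C)[C@H](N)CN(C(=O)[C@@H]1C[C@H]1c1ccccc1)c1ccc(-c2ccc(Oc3ccccc3)cc2)cc1` gives 94 nM, the lowest of the three, with compound 2 nearest and compound 1 furthest, both beyond the scatter. Compound 4 `CC[C@H](C)[C@H](N)CN(C(=O)[C@@H]1C[C@H]1c1ccccc1)c1ccc(-c2ccc(NC(C)=O)cc2)cc1` differs from compound 3 in one place: acetamido in place of phenoxy on an aromatic carbon. Among the compounds with values here, no measured pair shows this change, so its size is open. The numbers of compound 2 and compound 3 show the smaller para substituent with the higher number; on that basis the step from compound 3 to compound 4 is expected to raise the number, a 3.4-fold higher number from compound 3 to compound 4 (0.53 log units; beyond the scatter), beyond the scatter. Compound 4 is therefore estimated at 320 nM, within 100 nM to 1000 nM.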

Compound 4, half-maximal effective concentration: 5500 nM
Compound 4: middle estimate off by 17-fold (1.24 log units), on the low side; measured number above the stated range.
By their numbers in this assay, from the lowest: compound 3; then compound 2; then compound 1; then compound 4.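

In this assay, within the data shown here, the aromatic carbon para to a large group proves sensitive to its substituent: acetamido in place of phenoxy gives a 59-fold higher number from compound 3 to compound 4 (1.77 log units; beyond the scatter) as a large step, the first one-place comparison. This single change removes an aromatic ring and adds the amide hydrogen together, so the step cannot be assigned to either. No measurement at hand explains the step. Still open, going by these compounds, is whether a methoxy, an amino group or a benzyloxy at this carbon would stay nearer compound 3 or compound 4.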